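A few compounds are considered here, and "the series" means these few. Any claim that something is new, unique, unknown or untested is made for them only; others in the source may bear on it.

Of the compounds shown here, two of a shared core have been measured so far. Compound 1 `Clc1cccc2c1CC2CCCN1CCN(c2cccc3c2OCCO3)CC1` carries the chlorinated four-membered ring fused to an aromatic ring, and compound 2 `c1ccc2c(c1)CCCCC2CCN1CCN(c2cccc3c2OCCO3)CC1` carries the seven-membered ring fused to an aromatic ring. In an assay on isolated protein for binding affinity to 5-hydroxytryptamine receptor 1B (Rattus norvegicus) (on this read-out lower numbers stand for stronger inhibition and higher numbers for weaker inhibition), compound 1 gives 1100 nM, and compound 2 gives 776 nM. Compound 1 stands at the top of these two numbers, yet its gap to compound 2 lies within the usual scatter of repeated measurements, so the two cannot be told apart on these data alone.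

Compound 3 `c1ccc2c(c1)CCC2CCCN1CCN(c2cccc3c2OCCO3)CC1` has not yet been measured. It differs from compound 1 in one place: a group of 9 heavy atoms (9 carbon; one five-membered non-aromatic ring of carbon only, one six-membered aromatic ring of carbon only) in place of a group of 9 heavy atoms (8 carbon, 1 chlorine; one four-membered non-aromatic ring of carbon only, one six-membered aromatic ring of carbon only), on a saturated chain carbon, three bonds along the chain from an amine nitrogen in a ring. Going by the values given here, no two measured compounds differ in a single place, so there is no measured step that could guide the size of this change. Since compound 2 gives 776 nM with a different ring size at the same end of the molecule, the expectation is that compound 3 will not move far from the range already seen.

For compound 3 the expected step is a 1.4-fold lower number from compound 1 to compound 3 (0.14 log units; within the scatter), a small move lying within the scatter. Compound 3 is therefore estimated at 800 nM in this assay, with a likely range from 250 nM to 2500 nM.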

Compound 3, inhibition constant: 204 nM
The estimate for compound 3 lay 3.9-fold (0.59 log units) above the measured number, outside the stated range (below it).
By their numbers in this assay, from the lowest: compound 3; then compounds 2 and 1 (each within the scatter of the next).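

This position on the shared core proves sensitive to the group it carries: with the same count of heavy atoms entering as leaving, the 2,3-dihydro-1H-inden-1-yl group gives a 5.4-fold lower number from compound 1 to compound 3 (0.73 log units; beyond the scatter) in this assay and so stronger inhibition than the group it replaces. This first measured step shows that a change on a saturated chain carbon, three bonds along the chain from an amine nitrogen in a ring, can move the number beyond the scatter, even though neither group has a hydrogen-bond donor, a hydrogen-bond acceptor or a net charge. No measurement at hand says why the number moves.

From the compounds shown here alone, the step changes two things at once, the ring size and the presence of chlorine, and their separate shares remain unknown. A chlorine on the 2,3-dihydro-1H-inden-1-yl group, or the four-membered ring with a methoxy group in place of its chlorine, would begin to pull these two apart, while a longer chain carrying the 2,3-dihydro-1H-inden-1-yl group would test how much the chain itself matters.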